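Imidazole-linked diphenyl series: alcohol to methylamide

The compounds below may be only part of what the source reports. "The series", "measured", "known", "first", "only" and "open" are said of these compounds alone.

Measured compounds:
- compound 1, `Cc1nccn1CCCCCC(C(N)=O)(c1ccccc1)c1ccccc1`; in an assay on ileum with muscarinic acetylcholine receptor M3 (Cavia porcellus) as the target (on this read-out higher numbers stand for weaker inhibition and lower numbers for stronger inhibition), compound 1 gives 71.3 nM
- compound 2, `Cc1nccn1C(C)CC(C(N)=O)(c1ccccc1)c1ccccc1`; in this assay compound 2 gives 16.9 nM
- compound 3, `Cc1nccn1CCC(O)(c1ccccc1)c1ccccc1`; in this assay compound 3 gives 16.7 nM

Compound 3 holds the lowest number of the three, but compound 2 sits within the scatter of it, so no order between those two can be read. Compound 1, with its longer chain and primary carbamoyl group, sits beyond the scatter and clearly higher than compound 3. Within the data shown here, no pair of the measured compounds differs in only one place, so no single step has been quantified.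

Compound 4, `CNC(=O)C(CCn1ccnc1C)(c1ccccc1)c1ccccc1`, keeps the two-carbon link and the core of compound 3 and differs from it by methylcarbamoyl in place of hydroxy on a saturated chain carbon bound to two aromatic carbons and a saturated chain carbon. Among the measured compounds shown here, the measured set offers no direct precedent for exchanging the hydroxy against an amide on this carbon; compounds 1 and 2 carry a primary carbamoyl and also differ in the chain, so they cannot separate the two effects. Given that compound 2 with its carbamoyl group reaches 16.9 nM, an amide at this position is expected to be tolerated, and the step is expected to be small, at most a modest rise in this assay.

The estimate for compound 4 in this assay is 25 nM, within 8 nM to 80 nM, corresponding to an expected step of a 1.5-fold higher number from compound 3 to compound 4 (0.18 log units; within the scatter).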

Compound 4, antagonist equilibrium constant: 5150 nM
Compound 4: middle estimate off by 210-fold (2.31 log units), on the low side; the measured number lies above the stated range.
By their numbers in this assay, from the lowest: compounds 3 and 2 (each within the scatter of the next); then compound 1; then compound 4.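

In this assay, the series now has its first step that changes one place only: methylcarbamoyl in place of hydroxy on a saturated chain carbon bound to two aromatic carbons and a saturated chain carbon gives a 310-fold higher number from compound 3 to compound 4 (2.49 log units; beyond the scatter) in the direction of weaker inhibition. With the link and the core held as in compound 3, this single exchange moves the number far beyond the scatter, so this position is sharply sensitive to the change from hydroxy to methylcarbamoyl. Compounds 1 and 2 carry a primary carbamoyl but also differ from compound 4 in the chain, so their values cannot be set against this step or used to soften it.

Still open, as far as these compounds go, is whether the rise follows the methyl on the amide nitrogen or the carbonyl of the amide itself, a question that a primary carbamoyl on the chain of compound 4, or an amine, a methoxy group or a carboxylic acid at this carbon, could help to separate. The data shown contain no measurement that bears on the reason for this step.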